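The compounds below may be only part of what the source reports. "The series", "measured", "known", "first", "only" and "open" are said of these compounds alone.

Within the data shown here, only two members have been measured so far. In a functional assay on DU-145 cells (Homo sapiens) for inhibition, read by trypan blue exclusion, with a stated time of 96 h (on this read-out higher numbers stand for weaker inhibition of growth and lower numbers for stronger inhibition of growth), compound 1 (`Cc1ccc(S/C(=C/c2ccc(Br)cc2)C(=O)c2ccc(Cl)cc2)cc1`) gives 25000 nM and compound 2 (`CSc1ccc(/C=C(\C(=O)c2ccc(Br)cc2)S(=O)(=O)Cc2ccc(F)cc2)cc1`) gives 50000 nM so the two values stand within the scatter of each other. Compound 2 therefore sits level with compound 1 on the numbers available. Compound 3 (`O=C(/C(=C\c1ccc(O)cc1)S(=O)(=O)Cc1ccc(F)cc1)c1ccc(Br)cc1`) departs from compound 2 by a single change (hydroxy in place of methylsulfanyl on an aromatic carbon) with hydroxy in place of methylsulfanyl on an aromatic carbon. Among the measured compounds shown here, no measured pair isolates a change at this place, so the data fix neither its size nor its direction. A step within the scatter is expected in this assay with no firm direction. The estimated move is a 1.7-fold lower number from compound 2 to compound 3 (0.22 log units; within the scatter) and it is expected to stay small. Compound 3 is expected at 30000 nM within an estimated range of 8000 nM to 100000 nM on present evidence.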

Compound 3, concentration for 50% growth inhibition: 10000 nM
Compound 3: middle estimate off by 3.0-fold (0.48 log units), on the high side; low and high end bracket the measured number.
By their numbers in this assay, from the lowest: compound 3; then compounds 1 and 2 (each within the scatter of the next).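

In this assay, among these compounds, the exchange of methylsulfanyl for hydroxy on an aromatic carbon, para to a large group, gives the first step that can be read (a 5.0-fold lower number from compound 2 to compound 3 (0.70 log units; beyond the scatter)), and it lies beyond the scatter. This place therefore matters for growth inhibition in this series, and the change runs toward stronger inhibition, a direction that compound 1 and compound 2 could not show on their own. No measurement at hand accounts for the step.

Among the compounds shown here, one pair fixes only this one exchange: whether a methoxy group, an amine or a carboxylic acid at the same place would move the number as hydroxy does remains open. Also open, on these data alone, is whether the step holds when the groups elsewhere on the shared core differ.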